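Furan-2-yl for 3,4-Difluorophenyl: Estimating Compound 4

The compounds below may be only part of what the source reports. "The series", "measured", "known", "first", "only" and "open" are said of these compounds alone.

Measured compounds:
Compound 1 `COc1ccc(S(=O)(=O)n2ccc3cccc(-c4ccc(F)cc4)c32)cc1`: 202 nM
Compound 2 `COc1ccc(S(=O)(=O)N2CCc3cccc(-c4ccc(F)c(F)c4)c32)cc1`: 46 nM
Compound 3 `COc1ccc(S(=O)(=O)n2ccc3cccc(-c4ccc(C#N)cc4)c32)cc1`: 146 nM

In a functional assay on KB-VIN10 cells (Homo sapiens) for inhibition, with a stated time of 72 h (on this read-out higher numbers stand for weaker inhibition and lower numbers for stronger inhibition), compound 2 gives the lowest number of the three, with 46 nM. Compound 3 gives 146 nM and compound 1 gives 202 nM, both gaps to compound 2 lying beyond the scatter. For the measured compounds named here, compound 1 and compound 3 differ from compound 2 in two places, so no single step connects them to it.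

Compound 4 `COc1ccc(S(=O)(=O)N2CCc3cccc(-c4ccco4)c32)cc1` shares its core with compound 2 and differs from it in one place: furan-2-yl in place of 3,4-difluorophenyl on an aromatic carbon.

Going by the values given here, the only measured step, a 1.4-fold lower number from compound 1 to compound 3 (0.14 log units; within the scatter), swaps one substituent for another on the same six-membered ring and leaves the read-out within the scatter. Among the compounds with values here, it does not speak to replacing that ring by a five-membered one, so the present change has no direct precedent here. Given this, compound 4 is estimated to give a number somewhat higher than compound 2, a step of a 2.6-fold higher number from compound 2 to compound 4 (0.42 log units; beyond the scatter), but with wide uncertainty because the nearest measured step, a 1.4-fold lower number from compound 1 to compound 3 (0.14 log units; within the scatter), concerned a different kind of change. Compound 4 is therefore expected to give 120 nM, estimated to lie between 40 nM and 400 nM.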

Compound 4, half-maximal inhibitory concentration: 79.2 nM
Estimate against measurement, compound 4: 1.5-fold (0.18 log units) above, and the stated range covers the measured number.
By their numbers in this assay, from the lowest: compounds 2, 4, 3 and 1 (each within the scatter of the next, the first and the last beyond it).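

In this assay, furan-2-yl in place of 3,4-difluorophenyl gives a 1.7-fold higher number from compound 2 to compound 4 (0.24 log units; within the scatter) on the core of compound 2, so at this position the read-out of compound 4 cannot be told apart from that of compound 2. The earlier step concerned only a swap of one substituent for another on a six-membered aromatic ring of carbon only, whereas this one replaces that whole ring with a five-membered aromatic ring with 1 hetero atom, and it takes away both fluorines while adding a hydrogen-bond acceptor, with no separable effect on the read-out. Nothing shown here gives a measured property that could account for this outcome.

The compounds shown leave open whether this tolerance extends beyond aromatic rings, for instance to a morpholine, a carboxylic acid or a longer chain such as n-butyl at the same position. For the compounds shown here, they also leave open whether furan-2-yl would read the same way on the core of compound 1, which no single step here connects with the core of compound 2.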